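The compounds below may be only part of what the source reports. "The series", "measured", "known", "first", "only" and "open" are said of these compounds alone.

The study concerns two measured compounds and a third still to be tested, all built on the shared core. For the measured compounds named here, compound 1 `Cc1cc(C(=O)O)c(C)n1CC1CC1` is the weaker of the two measured members; in an assay on cells for inhibition of Palmitoleoyl-protein carboxylesterase NOTUM variant C330S (Homo sapiens), read by fluorescence, with a stated time of 40 min (on this read-out lower numbers stand for stronger inhibition and higher numbers for weaker inhibition), compound 1 gives 12700 nM. Compound 2 `Cc1cc(C(=O)O)c(C)n1-c1cccc(C#N)c1F` carries an aromatic ring bearing a fluoro group and a cyano, and in this assay compound 2 gives 630 nM, the lowest of the two numbers recorded so far, with compound 1 standing a long way above it, well beyond the usual scatter.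

Compound 3 `Cc1cc(C(=O)O)c(C)n1-c1ccccc1F` is the next compound to be measured. It differs from compound 2 in one place: hydrogen in place of cyano on an aromatic carbon. Going by the values given here, no pair of measured compounds shows this change, so its effect can only be estimated. Compound 2, at 630 nM, separates itself from compound 1 through its aromatic ring with fluoro and cyano, so removing the cyano is expected to cost some potency, and a step of a 3.2-fold higher number from compound 2 to compound 3 (0.50 log units; beyond the scatter) is anticipated, a weakening beyond the scatter yet smaller than the gap back to compound 1. Compound 3 is therefore expected to give about 2000 nM, with a plausible range from 800 nM to 6000 nM.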

Compound 3, half-maximal inhibitory concentration: 3300 nM
Compound 3: middle estimate off by 1.7-fold (0.22 log units), on the low side; the range from low to high includes it.
By their numbers in this assay, from the lowest: compound 2; then compound 3; then compound 1.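

In this assay, for the compounds shown here, replacing cyano with hydrogen on the aromatic carbon ortho to a fluoro group gives a 5.2-fold higher number from compound 2 to compound 3 (0.72 log units; beyond the scatter) and so puts a measured size on this change for the first time. The fluoro group and the shared core are the same in both compounds, which ties the modest loss, beyond the usual scatter, to this one place: the cyano contributes to the stronger inhibition of compound 2, and compound 3 shows that the fluoro-bearing ring without cyano keeps a weaker level of inhibition. Nothing available explains why the nitrile has this effect on the read-out.

Whether an amine, a methoxy group or a carboxylic acid on this same aromatic carbon would match the cyano, fall short of it or surpass it remains open, so the compounds shown do not tell whether the gain is special to the nitrile. From the compounds shown here alone, it is also open whether the cyano would bring a step of similar size if hydrogen stood in place of the fluoro group.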